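Swapping the Ketone Aryl Group: Nitrophenyl to Pyridinyl

The source may hold more compounds than are shown below. What is called first, only, known or untested is meant among the compounds shown, and "the series" means these compounds.

Three compounds share one core and differ only in the aryl group attached to the carbonyl carbon. In a functional assay on NCI-H1299 cells (Homo sapiens) for antiproliferative activity, read by XTT assay, with a stated time of 72 h (a lower number here means a stronger inhibitor, a higher number a weaker inhibitor), compound 1 `COc1ccc(-c2cc3ccccc3nc2/C=C/C(=O)c2ccc(F)cc2)cc1` gives 820 nM. Compound 2 `COc1ccc(C(=O)/C=C/c2nc3ccccc3cc2-c2ccc(OC)cc2)cc1` gives 6420 nM, and compound 3 `COc1ccc(-c2cc3ccccc3nc2/C=C/C(=O)c2ccc([N+](=O)[O-])cc2)cc1` gives 770 nM. Compound 3 has the lowest of the three numbers, but its gap to compound 1 is within the scatter (a 1.1-fold lower number from compound 1 to compound 3 (0.03 log units; within the scatter)), while a 7.8-fold higher number from compound 1 to compound 2 (0.89 log units; beyond the scatter) and an 8.3-fold lower number from compound 2 to compound 3 (0.92 log units; beyond the scatter) are beyond it.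

Compound 4 `COc1ccc(-c2cc3ccccc3nc2/C=C/C(=O)c2ccccn2)cc1` carries pyridin-2-yl in place of 4-nitrophenyl on a carbonyl carbon. Among the compounds with values here, none of the measured steps swaps the whole aryl ring; each only exchanges one group on an aromatic carbon, so they bear on the new change only loosely. Within the data shown here, because nitro against fluoro gave a 1.1-fold lower number from compound 1 to compound 3 (0.03 log units; within the scatter) while methoxy gave a 7.8-fold higher number from compound 1 to compound 2 (0.89 log units; beyond the scatter), the identity of this aryl group clearly moves the number, but a pyridin-2-yl has no counterpart among the three. The expectation is a modest loss, a 2.1-fold higher number from compound 3 to compound 4 (0.32 log units; beyond the scatter), with wide uncertainty. Compound 4 is estimated at 1600 nM, between 500 nM and 5500 nM.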

Compound 4, half-maximal inhibitory concentration: 660 nM
For compound 4 the middle estimate is 2.4-fold (0.38 log units) above the measured one; the measured number falls inside the stated range.
By their numbers in this assay, from the lowest: compounds 4, 3 and 1 (each within the scatter of the next); then compound 2.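

In this assay, exchanging the whole 4-nitrophenyl ring for pyridin-2-yl makes no difference beyond the scatter (a 1.2-fold lower number from compound 3 to compound 4 (0.07 log units; within the scatter)), and the same holds against the 4-fluorophenyl ring (a 1.2-fold lower number from compound 1 to compound 4 (0.09 log units; within the scatter)). The earlier compounds shown here only varied one group on a phenyl ring, whereas this result shows that the carbonyl carbon can also carry a ring with a hetero atom and no added group, while compound 2 remains the one apart (a 9.7-fold lower number from compound 2 to compound 4 (0.99 log units; beyond the scatter)). No measurement is available that would explain these numbers.

Going by these compounds, it stays open how an unsubstituted phenyl group would compare with pyridin-2-yl, which would show whether the ring nitrogen counts for anything here. Also open, on these data alone, is how this carbonyl carbon would respond to a 4-aminophenyl ring or to a non-aromatic group such as cyclohexyl.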